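The source may hold more compounds than are shown below. What is called first, only, known or untested is meant among the compounds shown, and "the series" means these compounds.

Working notes on the series. The shared core carries a benzylamine side chain and an aryl group at the position flanked by the two ring nitrogen atoms. Compound 1 `FC(F)(F)c1ccccc1-c1nc(NCc2ccc(-c3ccccc3)cc2)c2ccccc2n1` bears a 2-(trifluoromethyl)phenyl group there and a biphenyl tail; in an assay on a protein complex for inhibition of ubiquitin carboxyl-terminal hydrolase 1/WD repeat-containing protein 48 (Homo sapiens), read by fluorescence (a higher number here means a weaker inhibitor, a lower number a stronger inhibitor), compound 1 gives 3700 nM. Compound 2 `FC(F)(F)c1cccc(-c2nc(NCc3ccc(-c4cccnc4)cc3)c3ccccc3n2)c1` moves the trifluoromethyl to the other ring position and swaps the terminal phenyl for a pyridinyl; in this assay compound 2 gives "not active" (no number reported), so no single number is available for it, only the statement that it falls short of measurable inhibition. Compound 1 and compound 2 differ in two places at once, so their values are read side by side without a counted step.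

Compound 3 `c1cncc(-c2ccc(CNc3nc(-n4ccnc4)nc4ccccc34)cc2)c1` is the next entry, made from compound 2 by one change: 1H-imidazol-1-yl in place of 3-(trifluoromethyl)phenyl on an aromatic carbon. Going by the values given here, with compound 2 reported without a number, no step in this assay can be computed for this pair; given that compound 1 reaches only 3700 nM, any gain is expected to be modest and compound 3 is expected to remain weak. Compound 3 is estimated at 10000 nM in this assay, in a range from 2000 nM to 50000 nM, with a real chance that only a limit is reported.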

Compound 3, half-maximal inhibitory concentration: "not active" (no number reported)
Compound 3 has no reported number here; no gap can be computed for the estimate.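

In this assay compound 2 gives "not active" (no number reported) and compound 3 gives "not active" (no number reported), so no step can be read between them. No measured evidence bears on this result. The compounds shown leave open whether 1H-imidazol-1-yl in place of 3-(trifluoromethyl)phenyl changes inhibition at all, and which of the two differences between compound 1 and compound 2 matters.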